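Swapping a Dimethylphenyl for a Chlorophenyl Amide

This account rests on a few compounds, and the source may have more. Where it says the series, first, only, none or still open, it means among the compounds named here.

Compound 1 `Cc1cc(C)cc(NC(=O)CN2CCC(c3cccc[n+]3[O-])CC2)c1` is a small amide built on a piperidine core that carries a pyridine N-oxide. In a functional assay on HEK293 cells for agonist activity at D(4) dopamine receptor (Homo sapiens), read by FLIPR (a higher number here means a larger maximal response, a lower number a smaller maximal response), compound 1 gives 76%. This is the higher of the two measured numbers, but only just: its neighbour, compound 2 `N#Cc1cccc(C(=O)NCN2CCC(c3cccc[n+]3[O-])CC2)c1`, gives 69% in this assay, and the gap between the two falls inside the scatter of the measurement, so the two compounds cannot be told apart on these numbers.

Compound 3 `O=C(CN1CCC(c2cccc[n+]2[O-])CC1)Nc1cccc(Cl)c1` has not yet been measured. Within the data shown here, its only difference from compound 1 is 3-chlorophenyl in place of 3,5-dimethylphenyl on an amide-type nitrogen. Among the measured compounds shown here, no measured pair in this set changes just that part of the molecule, so there is no direct guide to the size of the step. With both measured compounds landing close together, the expectation is a step from compound 1 to compound 3 that stays within the scatter or is at most modest, a number 6 percentage points lower from compound 1 to compound 3 (within the scatter). Compound 3 is therefore estimated to give 70% in this assay, with a plausible range from 55% to 85%.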

Compound 3, largest response reached (reported as efficacy), in percent of the reference or control that the assay uses: 76%
Compound 3: middle estimate off by 6 percentage points, on the low side, and the stated range covers the measured number.
By their numbers in this assay, from the lowest: compounds 2, 1 and 3 (each within the scatter of the next).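

Among these compounds, compound 1 and compound 3 form the first pair here that changes only the aromatic ring on the amide-type nitrogen, and in this assay replacing 3,5-dimethylphenyl with 3-chlorophenyl gives no change at the digits printed from compound 1 to compound 3 (within the scatter). For this pair, the maximal response therefore cannot be told apart whether the ring carries two methyl groups or one chlorine, even though the entering group has one heavy atom fewer and a different kind of atom on the ring. No other measurement shown here offers an explanation for this result.

As far as these compounds go, one pair covers only a narrow slice of what this position could hold, so it remains open whether the response in this assay would also hold with an unsubstituted phenyl, a 3-methoxyphenyl, a pyridine ring or a cyclohexyl group on the amide-type nitrogen. From the compounds shown here alone, it is also open how a more drastic change, such as an amine or a carboxylic acid on the ring, would compare with compound 1, and whether the same swap would give a similar step on a different core.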